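Working notes: a second chloro added to compound 1

A few compounds are considered here, and "the series" means these few. Any claim that something is new, unique, unknown or untested is made for them only; others in the source may bear on it.

Measured:
compound 1 `O=C(O)CCc1ccc(C#Cc2ccnc(Cl)c2)cc1` — 94%
compound 2 `COc1cc(C#Cc2ccc(CCC(=O)O)cc2)ccn1` — 98%

In an in vitro functional assay on 1321-N1 cells for agonist activity at Free fatty acid receptor 1 (Homo sapiens), read by fluorescence, spectrophotometry and calcium flux (a lower number here means a smaller maximal response, a higher number a larger maximal response), compound 1 gives 94%, and compound 2 gives 98%; the two lie within the scatter of each other. Going by the values given here, the only measured step, a number 4 percentage points higher from compound 1 to compound 2 (within the scatter), is likewise within the scatter. Compound 3 `O=C(O)CCc1ccc(C#Cc2cc(Cl)nc(Cl)c2)cc1` differs from compound 1 by chloro in place of hydrogen on an aromatic carbon. Among the compounds with values here, no measured step covers this change; the one step seen, an exchange at a different position, moved nothing beyond the scatter, so no step beyond the scatter is expected in this assay here either. Compound 3 is expected to give 92%, within 75% to 105%. The step this estimate implies is a number 2 percentage points lower from compound 1 to compound 3 (within the scatter).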

Compound 3, largest response reached (reported as efficacy), in percent of the reference or control that the assay uses: 103%
Compound 3: the middle estimate sits 11 percentage points below what was measured; the measured number falls inside the stated range.
By their numbers in this assay, from the lowest: compounds 1, 2 and 3 (each within the scatter of the next).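

Chloro in place of hydrogen at this position, next to the ring nitrogen, gives a number 9 percentage points higher from compound 1 to compound 3 (within the scatter) in this assay, so the position accepts a second chloro with the maximal response kept within the scatter. Compounds 1 and 2 covered only an exchange of the existing substituent, whereas compound 3 adds a group at a ring hydrogen. No data on hand explain this outcome.

Open, as far as these compounds go, is whether an amine or a trifluoromethyl group would be accepted at this position as well. Only maximal response is shown, so potency remains open.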